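Swapping the benzyl arm: a bromine for one carbon

A few compounds are considered here, and "the series" means these few. Any claim that something is new, unique, unknown or untested is made for them only; others in the source may bear on it.

Two compounds share a core built around an aryl sulfamate, and they differ only in the amino group that sits on an aromatic carbon, para to a large group. Compound 1 `CN(CCN1CCCCC1)c1ccc(C(=O)N2CCc3ccc(OS(N)(=O)=O)cc3C2)cc1` carries methyl(2-(piperidin-1-yl)ethyl)amino there, and in an assay on HEK293 cells for inhibition of Steryl-sulfatase (Homo sapiens), tested at 0.1 uM (a higher number here means a stronger effect of the compound at the concentration tested, a lower number a weaker effect), compound 1 gives 0.3%. Compound 2 `CCCN(Cc1ccccc1)c1ccc(C(=O)N2CCc3ccc(OS(N)(=O)=O)cc3C2)cc1` carries benzyl(propyl)amino instead, and in this assay compound 2 gives 64.8%, the higher of the two numbers; the step of a number 64.5 percentage points higher from compound 1 to compound 2 (beyond the scatter) shows how strongly this position governs the read-out.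

Compound 3 `CCN(Cc1cccc(Br)c1)c1ccc(C(=O)N2CCc3ccc(OS(N)(=O)=O)cc3C2)cc1` keeps the core of compound 2 and changes that same group: (3-bromobenzyl)(ethyl)amino in place of benzyl(propyl)amino on an aromatic carbon. For the measured compounds named here, the one measured step bears on it only indirectly, since the aromatic ring of the benzyl part is kept while a bromine enters and the chain shortens. The step of a number 4.8 percentage points lower from compound 2 to compound 3 (within the scatter) is therefore expected to stay within the scatter. Compound 3 is estimated to give 60%, ranging from 35% to 85%.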

Compound 3, a percentage reported as inhibition, at one concentration (the size of the read-out at that concentration, not a potency): 80.2%
Compound 3: middle estimate off by 20.2 percentage points, on the low side; measured number inside the range.
By their numbers in this assay, from the lowest: compound 1; then compound 2; then compound 3.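

The step of a number 15.4 percentage points higher from compound 2 to compound 3 (beyond the scatter) in this assay shows that benzyl(propyl)amino is not the upper end for this position, and that the read-out can still rise when a bromine sits on the benzyl ring. The wider step a number 79.9 percentage points higher from compound 1 to compound 3 (beyond the scatter) adds a second benzyl-bearing group to the one already seen, and it too stands far above methyl(2-(piperidin-1-yl)ethyl)amino. No measurement on hand gives a reason for either step.

This one change adds a bromine and replaces propyl with ethyl at the same time, and the compounds shown do not tell which of the two carries the rise. Benzyl(ethyl)amino would separate the two, while a chlorine or a methoxy on the benzyl ring would test whether bromine itself matters.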